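Piperidinyl acetamide at the carbamate position of the core

The compounds below may be only part of what the source reports. "The series", "measured", "known", "first", "only" and "open" are said of these compounds alone.

Compound 1 `CCOC(=O)Nc1cccc2c1CN(C)CC2c1ccccc1` carries an ethoxy group on the carbonyl carbon and in a functional assay on the whole organism for inhibition of sodium-dependent dopamine transporter (Mus musculus) (a higher number here means that more compound is needed for the effect, a lower number that less compound is needed), compound 1 gives 2.5 mg/kg. Compound 2 `CCNCC(=O)Nc1cccc2c1CN(C)CC2c1ccccc1` gives about 60 mg/kg in this assay, and compound 3 `CCNCCC(=O)Nc1cccc2c1CN(C)CC2c1ccccc1` gives 190 mg/kg. Compound 3 therefore stands highest of the three numbers: the step of a 76-fold higher number from compound 1 to compound 3 (1.88 log units; beyond the scatter) is large, and the step of a 3.2-fold higher number from compound 2 to compound 3 (0.50 log units; beyond the scatter) is modest but beyond the scatter, so compound 3 needs more compound than either of its neighbours.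

Compound 4 `CN1Cc2c(NC(=O)CN3CCCCC3)cccc2C(c2ccccc2)C1` is not yet measured. Relative to compound 3 the change is piperidin-1-yl in place of (ethylamino)methyl on a saturated chain carbon bound to a carbonyl carbon. The step that bears most directly on this is a 3.2-fold higher number from compound 2 to compound 3 (0.50 log units; beyond the scatter), since the chain from the carbonyl carbon to the basic nitrogen in compound 4 is again one carbon long, as in compound 2, and the chain extension is thereby undone; the steps of a 24-fold higher number from compound 1 to compound 2 (1.38 log units; beyond the scatter) and a 76-fold higher number from compound 1 to compound 3 (1.88 log units; beyond the scatter) place both amine-bearing chains well above the carbamate. Within the data shown here, no measured pair shows the exchange of ethylamino for a piperidine ring, so that part of the change is uncharted. The working expectation is that compound 4 moves back toward compound 2, a step of a 3.2-fold lower number from compound 3 to compound 4 (0.50 log units; beyond the scatter), so that compound 4 is estimated at 60 mg/kg with a range of 20 mg/kg to 200 mg/kg.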

Compound 4, dose for half-maximal effect: about 60 mg/kg
Beside the measured number, compound 4's estimate shows no gap at the digits printed; the range from low to high includes it.
By their numbers in this assay, from the lowest: compound 1; then compounds 2 and 4 (each within the scatter of the next); then compound 3.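

With the chain held at one carbon, piperidin-1-yl in place of ethylamino leaves this assay unchanged, with no change at the digits printed from compound 2 to compound 4 (within the scatter), while a 3.2-fold lower number from compound 3 to compound 4 (0.50 log units; beyond the scatter) sets compound 4 apart from the longer-chain compound. The ring therefore adds no measurable separation from the open ethylamino group, and the exchange for compound 4 still gives a 24-fold higher number from compound 1 to compound 4 (1.38 log units; beyond the scatter), so neither amine-bearing group at this position, open or cyclic, comes near the ethoxy group of the carbamate. No measurement on hand explains these steps.

The compounds shown do not separate the chain length from the ring in the step to compound 3, since a 2-(piperidin-1-yl)ethyl group on the carbonyl carbon would be needed to test whether the longer chain raises the number with the ring in place as well. Also open, going by these compounds, is whether the ring size or the ring atoms matter at all, as a pyrrolidine or a morpholine on the same saturated chain carbon bound to the carbonyl carbon would show.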